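Pyridin-2-yl in place of phenyl: expected step from compound 1

This account rests on a few compounds, and the source may have more. Where it says the series, first, only, none or still open, it means among the compounds named here.

Compound 1, `O=C1O/C(=C\Cn2cc(-c3ccccc3)nn2)C(OCc2ccccc2)=C1OCc1ccccc1`: in a functional assay on PC-3 cells (Homo sapiens) for antiproliferative activity, read by MTT assay, with a stated time of 24 h (a higher number here means a weaker inhibitor, a lower number a stronger inhibitor), compound 1 gives > 100000 nM, which is a limit of the assay and not a number.
Compound 2, `O=C1NC(O)(CCn2cc(Cc3ccccc3)nn2)C(OCc2ccccc2)=C1OCc1ccccc1`: in this assay compound 2 gives > 100000 nM, again only a limit.
Compound 3, `CCCc1cn(CCC2(O)C(OCc3ccccc3)=C(OCc3ccccc3)C(=O)N2CCC)nn1`: in this assay compound 3 gives 35000 nM.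

Compound 1 stands at the limit of > 100000 nM in this assay, at which 2 of the 3 values shown sit, so only a limit is known for it, and one further value in the set is likewise a limit. Among the compounds with values here, no step between two measured compounds that differ in one place is available, so the size of a single change has not been tested within this set.

Compound 4, `O=C1O/C(=C\Cn2cc(-c3ccccn3)nn2)C(OCc2ccccc2)=C1OCc1ccccc1`, differs from compound 1 by pyridin-2-yl in place of phenyl on an aromatic carbon. Nothing measured here speaks for a gain or a loss from this change beyond the scatter. Compound 4 is therefore expected to stay where compound 1 stands, with an estimated 100000 nM and a range from 30000 nM to 300000 nM. The expected step of a number no higher from compound 1 to compound 4 (the limit leaves the size open) is none beyond the scatter, and most likely compound 4 again returns only a limit.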

Compound 4, half-maximal inhibitory concentration: > 100000 nM
Compound 4: a limit, no number (the forecaster's own chance of this, stated with the estimate: 70%); the middle value lies on the limit itself.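

In this assay compound 1 and compound 4 each return only a limit of the assay, so no step can be read between them: the limit of > 100000 nM in this assay, at which 3 of the 4 values shown sit.

The compounds shown leave open whether pyridin-2-yl in place of phenyl on the shared core changes antiproliferative activity at all, and by how much.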